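The source may hold more compounds than are shown below. What is called first, only, known or untested is meant among the compounds shown, and "the series" means these compounds.

Compound 1 `CC(C)[C@@H](NC(=O)c1cccc(F)c1)C(=O)N1CCC(c2ccc(Cl)cc2)CC1` gives 24 nM in an assay on THP-1 cells for displacement of a labelled ligand from C-C chemokine receptor type 1 (Homo sapiens); a lower number here means a stronger inhibitor, a higher number a weaker inhibitor.
Compound 2 `CC(C)[C@@H](NC(=O)CCCc1ccccc1)C(=O)N1CCC(c2ccc(Cl)cc2)CC1` gives 95 nM in this assay.
Compound 3 `Cc1cccc(CCC(=O)N[C@@H](C(=O)N2CCC(c3ccc(Cl)cc3)CC2)C(C)C)c1` gives 22 nM in this assay.

Compound 3 has the lowest number of the three, but the step of a 1.1-fold lower number from compound 1 to compound 3 (0.04 log units; within the scatter) lies within the scatter, so those two cannot be told apart; only compound 2 stands clearly apart, as a 4.3-fold lower number from compound 2 to compound 3 (0.64 log units; beyond the scatter) shows. Compound 4 `CC(C)[C@@H](NC(=O)Nc1ccccc1)C(=O)N1CCC(c2ccc(Cl)cc2)CC1` has not yet been measured. It differs from compound 3 by anilino in place of 2-(3-methylphenyl)ethyl on a carbonyl carbon. The measured steps that bear on this all swap the group on the same carbonyl carbon: a 4.0-fold higher number from compound 1 to compound 2 (0.60 log units; beyond the scatter) was a modest worsening on lengthening the link to the aromatic ring, while a 1.1-fold lower number from compound 1 to compound 3 (0.04 log units; within the scatter) and a 4.3-fold lower number from compound 2 to compound 3 (0.64 log units; beyond the scatter) show that a ring held on a shorter link recovers the lower number. Anilino is another such group, but it brings a hydrogen-bond donor that no measured group has, so no step covers it exactly. A small step in this assay, not clearly beyond the scatter, is expected, a 1.8-fold higher number from compound 3 to compound 4 (0.26 log units; within the scatter). Compound 4 is therefore estimated at 40 nM, between 10 nM and 160 nM.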

Compound 4, half-maximal inhibitory concentration: 616 nM
The estimate for compound 4 lay 15-fold (1.19 log units) below the measured number, outside the stated range (above it).
By their numbers in this assay, from the lowest: compounds 3 and 1 (each within the scatter of the next); then compound 2; then compound 4.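

Among these compounds, on this carbonyl carbon, anilino is the first group to push the number far up in this assay, with a 28-fold higher number from compound 3 to compound 4 (1.45 log units; beyond the scatter) and a 26-fold higher number from compound 1 to compound 4 (1.41 log units; beyond the scatter), and even the weakest earlier compound is left behind, with a 6.5-fold higher number from compound 2 to compound 4 (0.81 log units; beyond the scatter). Compound 4 keeps one six-membered aromatic ring, as the others do, so having such a ring on this side of the carbonyl does not by itself secure a low number, and compound 4 is the weakest of the four. Nothing measured here explains the rise.

From the compounds shown here alone, it remains open whether the nitrogen itself matters, which benzylamino or benzyloxy on this carbonyl carbon could help to test. Also open, going by these compounds, is whether a methyl or a fluorine on the anilino ring, as on the rings of compound 3 and compound 1, would bring the number down.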